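This account rests on a few compounds, and the source may have more. Where it says the series, first, only, none or still open, it means among the compounds named here.

Measured in a functional assay on HCT-116 cells (Homo sapiens) for antiproliferative activity, read by MTT assay, with a stated time of 48 h; on this read-out lower numbers stand for stronger inhibition and higher numbers for weaker inhibition:
compound 1, `CS(=O)(=O)c1ccc(Nc2nccc(Nc3nc4ccc(F)cc4s3)n2)cc1`, 860 nM
compound 2, `Cc1cnc(Nc2ccc(S(C)(=O)=O)cc2)nc1Nc1nc2ccc(F)cc2s1`, 24000 nM
compound 3, `CS(=O)(=O)c1ccc(Nc2nccc(Nc3nc4ccccc4s3)n2)cc1`, 8370 nM
Not yet measured: compound 4, `Cc1ccc2nc(Nc3ccnc(Nc4ccc(S(C)(=O)=O)cc4)n3)sc2c1`.

The cores of compound 1 and compound 3 differ by hydrogen in place of fluoro on an aromatic carbon; this gave a 9.7-fold higher number from compound 1 to compound 3 (0.99 log units; beyond the scatter) in this assay. The change methyl in place of hydrogen on an aromatic carbon gave a 28-fold higher number from compound 1 to compound 2 (1.45 log units; beyond the scatter). Compound 4 carries the same kind of change on the core of compound 3, (methyl in place of hydrogen on an aromatic carbon), but not the same one: in compound 2 the methyl sits on a six-membered aromatic ring with 2 nitrogen, ortho and para to a large group, whereas in compound 4 it sits on a six-membered aromatic ring of carbon only, part of a fused system, meta and para to a fused ring. The large loss in compound 2 therefore need not carry over. Compound 4 is expected to give 5000 nM, a step of a 1.7-fold lower number from compound 3 to compound 4 (0.22 log units; within the scatter), within 1200 nM to 20000 nM.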

Compound 4, half-maximal inhibitory concentration: 1750 nM
The estimate for compound 4 lay 2.9-fold (0.46 log units) above the measured number, within the range that was stated.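

In this assay, methyl in place of hydrogen on an aromatic carbon does not carry from one core to another, even in direction: the same change on two cores in this assay, a 28-fold higher number (1.45 log units; beyond the scatter) from compound 1 to compound 2 and a 4.8-fold lower number (0.68 log units; beyond the scatter) from compound 3 to compound 4, 130-fold (2.13 log units) apart, beyond the scatter of two such steps

On the six-membered aromatic ring of carbon only, the change gave a 4.8-fold lower number from compound 3 to compound 4 (0.68 log units; beyond the scatter), and methyl in place of fluoro at the same place gave a 2.0-fold higher number from compound 1 to compound 4 (0.31 log units; beyond the scatter), so fluoro remains the best of the three substituents there. The two methyl steps differ in both the ring carrying the methyl and the starting core, so this pair cannot show which of these sets the gap.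

Open, going by these compounds, is whether chloro or methoxy at that place would match fluoro. Also open, on these data alone, is whether methyl on the six-membered aromatic ring with 2 nitrogen would cost as much on the core of compound 3.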